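Swapping the Piperazine Tail for a Hydroxypiperidine

This account rests on a few compounds, and the source may have more. Where it says the series, first, only, none or still open, it means among the compounds named here.

Measured compounds:
- compound 1, `O=C1c2c[n+]([O-])c3ccccc3c2C(=O)c2c1c1ccccc1n2Cc1cn(C[C@@H](O)CO)nn1`: 670 nM
- compound 2, `O=C1c2c[n+]([O-])c3ccccc3c2C(=O)c2c1c1ccccc1n2CCCCN1CCNCC1`: 3310 nM
- compound 3, `CCCN1CCN(CCCCn2c3c(c4ccccc42)C(=O)c2c[n+]([O-])c4ccccc4c2C3=O)CC1`: 2980 nM

These three compounds share one core and differ only in the chain hanging from the aromatic nitrogen. In a functional assay on MDA-MB-231 cells (Homo sapiens) for cytotoxicity, read by MTT assay, with a stated time of 72 h (a lower number here means a stronger inhibitor, a higher number a weaker inhibitor), compound 3 gives 2980 nM, the second highest of the three numbers; it sits close to compound 2, with a 1.1-fold lower number from compound 2 to compound 3 (0.05 log units; within the scatter), while compound 1 is clearly stronger, with a 4.4-fold higher number from compound 1 to compound 3 (0.65 log units; beyond the scatter).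

Compound 4, `O=C1c2c[n+]([O-])c3ccccc3c2C(=O)c2c1c1ccccc1n2CCCN1CCC(O)CC1`, has not yet been measured. It differs from compound 3 as follows: 4-hydroxypiperidin-1-yl in place of (4-propylpiperazin-1-yl)methyl on a saturated chain carbon, three bonds along the chain from an aromatic nitrogen.

Two measured steps inform this change. Adding propyl to the ring amine nitrogen made no difference beyond the scatter (a 1.1-fold lower number from compound 2 to compound 3 (0.05 log units; within the scatter)), so losing that propyl is unlikely to matter. Replacing a triazole carrying a dihydroxypropyl group with a piperazine chain weakened the compound modestly (a 4.9-fold higher number from compound 1 to compound 2 (0.69 log units; beyond the scatter)), which hints that a hydroxyl-bearing tail may be tolerated or mildly helpful. Among the measured compounds shown here, the ring shrinks from two heteroatoms to one and the chain shortens, for which no measured step exists. For compound 4 a small step toward a lower number is therefore expected, a 1.3-fold lower number from compound 3 to compound 4 (0.11 log units; within the scatter), with an estimated value of 2300 nM (range 1000 nM to 5300 nM).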

Compound 4, half-maximal inhibitory concentration: 280 nM
Estimate against measurement, compound 4: 8.2-fold (0.91 log units) above; the measured number lies below the stated range.
By their numbers in this assay, from the lowest: compound 4; then compound 1; then compounds 3 and 2 (each within the scatter of the next).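

In this assay, among the compounds shown here, the earlier compounds showed only that adding propyl to the ring amine nitrogen changed nothing beyond the scatter, which could have suggested that the far end of this chain matters little. Compound 4 shows that the tail at this place can matter a great deal: the change to 4-hydroxypiperidin-1-yl gives an 11-fold lower number from compound 3 to compound 4 (1.03 log units; beyond the scatter) and a 12-fold lower number from compound 2 to compound 4 (1.07 log units; beyond the scatter), both large, and the result also passes the triazole compound, with a 2.4-fold lower number from compound 1 to compound 4 (0.38 log units; beyond the scatter), so compound 4 is the most potent of the four. The ring and the chain length change together in these steps, and nothing measured here says which of the two accounts for the gain.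

The compounds shown leave open whether the hydroxyl itself matters, which a plain piperidine or an amine in place of the hydroxyl on the same chain would help to test. They also leave open how 4-hydroxypiperidin-1-yl behaves on a longer chain, which would separate the effect of the ring from that of the chain length.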